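This account rests on a few compounds, and the source may have more. Where it says the series, first, only, none or still open, it means among the compounds named here.

Measured so far in the series:

Compound 1, `Nc1ncnc2c1ncn2[C@@H]1O[C@@]2(CO)CO[C@@H]1[C@@H]2O`, in a functional assay for antagonist activity at adenosine receptor A3 (Homo sapiens), with a stated time of 30 min (a lower number here means a stronger inhibitor, a higher number a weaker inhibitor), is reported only as a limit, > 100000 nM.
Compound 2, `CNC(=O)[C@@]12CO[C@@H]([C@H](n3cnc4c(N)ncnc43)O1)[C@@H]2O`, in this assay is reported only as a limit, > 100000 nM.
Compound 3, `Nc1ncnc2c1ncn2[C@@H]1O[C@@]2(CO)CN[C@@H]1[C@@H]2O`, in this assay is reported only as a limit, > 100000 nM.

Every value in hand sits at the limit of > 100000 nM in this assay, at which 3 of the 3 values shown sit. Among the compounds with values here, no compound therefore shows measurable antagonist activity, and no ordering among compound 1, compound 2 and compound 3 can be drawn.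

One structural change has been made within measured pairs: from compound 1 to compound 2, (methylcarbamoyl in place of hydroxymethyl on a saturated ring carbon). The step that the two limits leave unreadable from compound 1 to compound 2 has no readable size because both ends sit at the limit of > 100000 nM in this assay, at which 3 of the 3 values shown sit.

Compound 4, `CNC(=O)[C@@]12CN[C@@H]([C@H](n3cnc4c(N)ncnc43)O1)[C@@H]2O`, awaits measurement in this assay. It carries the same change relative to compound 3: methylcarbamoyl in place of hydroxymethyl on a saturated ring carbon. The place of the change is described in the same words in both pairs. How the core of compound 3 differs from the core of compound 1 is not broken down here.

For the step from compound 3 to compound 4 the expectation is a number no higher from compound 3 to compound 4 (the limit leaves the size open), resting on compound 3 sitting at the limit of > 100000 nM in this assay, at which 3 of the 3 values shown sit, and on the same change leaving compound 2 at the limit of > 100000 nM in this assay, at which 3 of the 3 values shown sit. Compound 4 is expected to give about 100000 nM, within 30000 nM to 300000 nM, with a further limit rather than a number the likelier outcome.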

Compound 4, half-maximal inhibitory concentration: 170 nM
Estimate against measurement, compound 4: 590-fold (2.77 log units) above, and the stated range ends above it.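

In this assay, methylcarbamoyl in place of hydroxymethyl on a saturated ring carbon brings an at least 580-fold lower number from compound 3 to compound 4 (2.76 log units; beyond the scatter), and since the starting end is a limit, the true size of this step is not known. On the core of compound 1, the same change gives compound 2, which remains a limit, > 100000 nM. The change therefore does not carry over as a general gain from one core to the other: the step between compound 1 and compound 2 cannot be read, only one pair gives a measurable value, and two pairs cannot show which feature of the cores separates the outcomes, with most values still at the limit: the limit of > 100000 nM in this assay, at which 3 of the 4 values shown sit.

Left open is whether methylcarbamoyl is specifically needed on the core of compound 3, or whether a carboxylic acid, a primary carboxamide or ethylcarbamoyl at the same place would also give a measurable value. Also open, on these data alone, is how far the value of compound 4, 170 nM, would move with a longer chain on the amide nitrogen, or with an amine in place of the methylcarbamoyl.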